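From cyclohexyl to 4-ethylphenyl on an amine nitrogen

The compounds below may be only part of what the source reports. "The series", "measured", "known", "first", "only" and "open" are said of these compounds alone.

Compound 1 `O=C1C=C(NCc2ccccc2)C(=O)c2c1nc1n2[C@H]2OC[C@@H](O)[C@H]2OC1` gives > 8000 nM
Compound 2 `O=C1C=C(NC2CCCCC2)C(=O)c2c1nc1n2[C@H]2OC[C@@H](O)[C@H]2OC1` gives > 16000 nM

In a functional assay on HeLa cells (Homo sapiens) for inhibition, read by sulforhodamine B assay (a lower number here means a stronger inhibitor, a higher number a weaker inhibitor), compound 2 gives > 16000 nM as a limit and not a number. Compound 1 gives > 8000 nM as a limit too. Compound 2 therefore has no measured potency and cannot be ranked against compound 1.

Compound 3 `CCc1ccc(NC2=CC(=O)c3nc4n(c3C2=O)[C@H]2OC[C@@H](O)[C@H]2OC4)cc1` has not yet been measured. The change 4-ethylphenyl in place of cyclohexyl on an amine nitrogen puts 4-ethylphenyl in place of cyclohexyl on an amine nitrogen, and the rest of the structure stays the same.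

Within the data shown here, the one measured step that bears on this is a step that the two limits leave unreadable from compound 1 to compound 2 and it changes the group on that same nitrogen. Its size cannot be read, so it offers neither a size nor a direction to carry over. Neither group has yet produced a number in this assay and compound 3 is expected to remain weak, with no step beyond the usual scatter. The expected step is an at least 1.3-fold lower number from compound 2 to compound 3 (0.12 log units; that floor lies within the scatter) and it is only an estimate. Compound 3 is expected at 12000 nM in this assay with an estimated range from 3000 nM to 40000 nM for its measurement.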

Compound 3, half-maximal inhibitory concentration: 3990 nM
Compound 3: middle estimate off by 3.0-fold (0.48 log units), on the high side, and the stated range covers the measured number.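

In this assay, compound 3 is the first of these compounds to give a number and not a limit, which shows that the group on this amine nitrogen can bring the read-out into the measurable range. Putting 4-ethylphenyl in place of cyclohexyl gives an at least 4.0-fold lower number from compound 2 to compound 3 (0.60 log units; beyond the scatter), and that size is only a floor because the step starts from a limit: the limit of > 16000 nM in this assay, at which 1 of the 3 values shown sits. Putting 4-ethylphenyl in place of benzyl gives an at least 2.0-fold lower number from compound 1 to compound 3 (0.30 log units; that floor lies within the scatter), again only a floor because this step also starts from a limit: the limit of > 8000 nM in this assay, at which 1 of the 3 values shown sits.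

The step between benzyl and cyclohexyl still cannot be read, and the compounds shown do not separate the part played by the aromatic ring from that of its ethyl group. A plain phenyl on the same nitrogen would divide those two contributions, and a longer chain in place of the ethyl group would show whether the number moves further with the size of that substituent.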